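The compounds below may be only part of what the source reports. "The series", "measured", "known", "first", "only" and "open" are said of these compounds alone.

Working notes on the cytotoxicity series in an ADME assay on HeLa cells (Homo sapiens) for cytotoxicity, read by ATP content, with a stated time of 3 days; on this read-out higher numbers stand for lower toxicity in this test and lower numbers for higher toxicity in this test.

Compound 3 `CC(C)CCn1c(Cn2c(=O)n(C3CC3)c3ccncc32)nc2ncccc21` gives only a limit in this assay, > 100000 nM. Its two neighbours likewise give limits rather than numbers. Compound 1 `CC(C)CCn1c(Cn2c(=O)n(C3CC3)c3ccncc32)nc2nc(Cl)ccc21` sits at the limit > 50000 nM. Compound 2 `O=c1n(Cc2nc3nc(Cl)ccc3n2CCCCO)c2cnccc2n1C1CC1` sits at the limit > 50000 nM. The two single-point steps that have been walked are therefore not readable: a step that the two limits leave unreadable from compound 1 to compound 2 and a step that the two limits leave unreadable from compound 1 to compound 3, since the values on both sides are bounds only. Within the data shown here, the whole picture so far is the limit of > 100000 nM in this assay, at which 1 of the 3 values shown sits, together with the limit of > 50000 nM in this assay, at which 2 of the 3 values shown sit, with no compound yet placed at a number.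

Compound 4 `O=c1n(Cc2nc3ncccc3n2CCCCO)c2cnccc2n1C1CC1` differs from compound 3 by 2-hydroxyethyl in place of isopropyl on a saturated chain carbon, two bonds along the chain from an aromatic nitrogen. The same exchange, from compound 1 to compound 2, left both ends at limits and so carries no readable size. Compound 4 is expected to remain at or beyond the bounds seen, with a step that the limit leaves unreadable from compound 3 to compound 4 expected to be no step beyond the scatter. The estimate for compound 4 is 150000 nM, with a range of 50000 nM to 500000 nM, and most probably this assay will again report only a limit.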

Compound 4, half-maximal cytotoxic concentration: > 100000 nM
Compound 4 gave a limit, no number; the forecaster's own chance of this, stated with the estimate: 85%; the middle value is on the limit's open side.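

In this assay compound 4 gives only a limit, as do compound 2 and compound 3, so the steps to compound 4 from compound 3 and from compound 2 cannot be read. The compounds shown leave open where any of them would fall as a number, and whether either exchange shifts the read-out at all.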